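Removing the trifluoromethyl group: expected effect on clearance

The compounds below may be only part of what the source reports. "The series", "measured", "known", "first", "only" and "open" are said of these compounds alone.

Two compounds built on the shared core differ only in the substituent on the pendant six-membered aromatic ring. Compound 1 `CNc1nc(NCCCN(C)C)c2sc(-c3ccc(-n4cccn4)cc3)cc2n1` gives 18.4 uL/min in an ADME assay (liver) for metabolic stability, with Liver microsome (Homo sapiens) as the target, read by LC-MS, using microsomes, tested at 1 uM; on this read-out lower numbers stand for slow clearance and higher numbers for fast clearance. Compound 2 `CNc1nc(NCCCN(C)C)c2sc(-c3cccc(C(F)(F)F)c3)cc2n1` gives 55.8 uL/min in this assay. Of the two numbers, compound 2 stands highest; its nearest neighbour, compound 1, sits at a lower number, and the gap between them lies beyond the usual scatter. Going by the values given here, no step between measured compounds that differ in one place is available, so nothing can yet be said about how single changes on this ring move the read-out.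

Compound 3 `CNc1nc(NCCCN(C)C)c2sc(-c3ccccc3)cc2n1` has not been measured in this assay. It differs from compound 2 as follows: hydrogen in place of trifluoromethyl on an aromatic carbon. The step from compound 2 to compound 3 is expected to be a 1.5-fold lower number from compound 2 to compound 3 (0.17 log units; within the scatter), a modest move toward a lower number that may well remain within the scatter of repeated measurements. Compound 3 is estimated at 38 uL/min, with a range from 16 uL/min to 90 uL/min reflecting the absence of any comparable step among the measured compounds.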

Compound 3, intrinsic clearance in a liver preparation (reported as CLH), per the amount of preparation that the assay uses in the Liver microsome assay: 5 uL/min
Compound 3: middle estimate off by 7.6-fold (0.88 log units), on the high side; measured number below the stated range.
By their numbers in the Liver microsome assay, from the lowest: compound 3; then compound 1; then compound 2.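

In the Liver microsome assay the unsubstituted ring of compound 3 gives the lowest number of the three, with hydrogen in place of trifluoromethyl giving an 11-fold lower number from compound 2 to compound 3 (1.05 log units; beyond the scatter) and hydrogen in place of 1H-pyrazol-1-yl giving a 3.7-fold lower number from compound 1 to compound 3 (0.57 log units; beyond the scatter) as well, so the first step is large and the second modest, and neither substituent carries a lower number than hydrogen on this ring. In a physicochemical assay for solubility, at pH 2 (a higher number here means a more soluble compound, a lower number a less soluble compound), compound 2 gives 180 ug/mL as its solubility at this pH. For compound 3, the physicochemical assay returns > 100 ug/mL as a limit of the assay and not a number, and the solubility step to it cannot be read: the limit of > 100 ug/mL in the physicochemical assay, at which 1 of the 2 values shown sits.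

As far as these compounds go, whether a small group such as fluorine, methyl or methoxy in place of trifluoromethyl would stay close to compound 3 or move toward compound 2 remains open, so the three compounds fix only the two ends of a possible trend on this ring. Also open, from the compounds shown here alone, is whether the same order of the three would hold with a morpholine at the end of the side chain on the shared core.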